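Aryl amide exchange, compound 3 to compound 4

The source may hold more compounds than are shown below. What is called first, only, known or untested is meant among the compounds shown, and "the series" means these compounds.

Measured so far:
compound 1 `CN(C)c1cccc(C(=O)N2CCC(n3cncc3-c3ccc(OS(=O)(=O)c4cccc5cnccc45)cc3)CC2)c1`: 155 nM in an assay on HEK293 cells for antagonist activity at P2X purinoceptor 7 (Homo sapiens), read by fluorescence, with a stated time of 2 h; on this read-out lower numbers stand for stronger inhibition and higher numbers for weaker inhibition
compound 2 `COc1ccc(C(=O)N2CCC(n3cncc3-c3ccc(OS(=O)(=O)c4cccc(C#N)c4)cc3)CC2)cc1`: 312 nM in this assay
compound 3 `O=C(c1ccc(Cl)c(C(F)(F)F)c1)N1CCC(c2nc3cc(OS(=O)(=O)c4cccc5cnccc45)ccc3[nH]2)CC1`: 31 nM in this assay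

Compound 3 has the lowest number of the three in this assay. The nearest is compound 1, whose number is higher by a margin beyond the scatter; compound 2 stands furthest, also beyond the scatter. Among the measured compounds shown here, compounds 1 and 2 share a core that is not the core of compound 3, and their aryl amides differ from one another as well, so no pair among the measured compounds is separated by a single change.

Compound 4 `CS(=O)(=O)c1ccc(C(=O)N2CCC(c3nc4cc(OS(=O)(=O)c5cccc6cnccc56)ccc4[nH]3)CC2)cc1` keeps the core and the sulfonate part of compound 3 and changes only the aryl group on the amide: 4-(methylsulfonyl)phenyl in place of 4-chloro-3-(trifluoromethyl)phenyl on a carbonyl carbon. For the measured compounds named here, no measured pair isolates a change of this kind, so the expectation rests on compound 3 alone, with a wide allowance for uncertainty. The step is expected to be modest, towards a higher number, close to the edge of the scatter: a 2.6-fold higher number from compound 3 to compound 4 (0.41 log units; beyond the scatter). Compound 4 is estimated at 80 nM in this assay, with a range from 20 nM to 400 nM.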

Compound 4, half-maximal inhibitory concentration: 7 nM
Beside the measured number, compound 4's estimate is 11-fold (1.06 log units) above it, outside the stated range (below it).
By their numbers in this assay, from the lowest: compound 4; then compound 3; then compounds 1 and 2 (each within the scatter of the next).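

The aryl group on the carbonyl carbon is now the one place in the series that can be read through a single change: in this assay, 4-(methylsulfonyl)phenyl in place of 4-chloro-3-(trifluoromethyl)phenyl gives a 4.4-fold lower number from compound 3 to compound 4 (0.65 log units; beyond the scatter) on an unchanged core and sulfonate part. On this core, then, neither the chlorine nor the trifluoromethyl group is required for a low number, and an aryl group with 2 hydrogen-bond acceptors reads lower than one with 0 hydrogen-bond acceptors. No measurement on hand speaks to what lies behind the step.

Going by these compounds, with a single pair, the step cannot be divided among loss of the chlorine, loss of the trifluoromethyl group and gain of the methylsulfonyl group, and whether the same exchange carries over to the core of compound 1 remains open. A carboxylic acid or a primary sulfonamide in place of the methylsulfonyl group would test how far this position reaches beyond the one sulfone-bearing aryl group shown here.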